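The compounds below may be only part of what the source reports. "The series", "measured", "known", "first", "only" and "open" are said of these compounds alone.

Series built on the shared core of compound 1 `Cc1ccc(S(=O)(=O)N[C@@H](CC(=O)NC(C)(C)C)C(=O)NCCNC(=O)c2cc(C)ccc2F)cc1`, with the terminal acyl or sulfonyl group on the chain amine varied. In an ADME assay on Karpas-1106P cells (Homo sapiens) for cytotoxicity (a higher number here means that more compound is needed for the effect, a lower number that less compound is needed), compound 1 reaches only the assay limit > 11100 nM and gives no number. Compound 2 `Cc1ccc(S(=O)(=O)N[C@@H](CC(=O)NC(C)(C)C)C(=O)NCCNS(=O)(=O)c2ccccc2)cc1` likewise stops at the limit > 11100 nM in this assay. Compound 3 `Cc1ccc(S(=O)(=O)N[C@@H](CC(=O)NC(C)(C)C)C(=O)NCCNC(=O)c2cccc(C(F)(F)F)c2)cc1` also returns only the limit > 11100 nM in this assay. Compound 2 thus stands at the limit of > 11100 nM in this assay, at which 3 of the 3 values shown sit, with nothing resolved among the three. The steps a step that the two limits leave unreadable from compound 1 to compound 2 and a step that the two limits leave unreadable from compound 2 to compound 3 carry no readable size. Compound 4 `Cc1ccc(S(=O)(=O)N[C@@H](CC(=O)NC(C)(C)C)C(=O)NCCNC(=O)c2cccc(C#N)c2)cc1` differs from compound 2 by (3-cyanophenyl)carbonyl in place of phenylsulfonyl on an amine nitrogen. With both neighbouring steps unreadable, no step beyond the scatter is expected in this assay, that is a step that the limit leaves unreadable from compound 2 to compound 4. Compound 4 is therefore expected near 20000 nM, within 8000 nM to 60000 nM, most likely again only a limit.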

Compound 4, half-maximal effective concentration: > 11100 nM
Compound 4: a limit, no number; the forecaster's own chance of this, stated with the estimate: 85%; the middle value is on the limit's open side.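

Compound 4 returns only a limit in this assay, so no step from compound 1, compound 2 or compound 3 to compound 4 can be read: the limit of > 11100 nM in this assay, at which 4 of the 4 values shown sit.

The compounds shown leave open whether any terminal group on the chain amine gives a number in this assay rather than a limit.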